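Pyrazoline series: hydroxyphenyl variation on the saturated ring carbon

This account rests on a few compounds, and the source may have more. Where it says the series, first, only, none or still open, it means among the compounds named here.

Measured compounds:
Compound 1 `CC(C)(C)C1=NN(c2ccc(C(=O)O)cc2)C(c2ccc(O)cc2)C1` — in an assay on isolated protein for inhibition of protein kinase C zeta type (Homo sapiens), with a stated time of 4 min (a higher number here means a weaker inhibitor, a lower number a stronger inhibitor), compound 1 shows "not determined" (no result reported)
Compound 2 `Cc1cccc(N2N=C(C(C)(C)C)CC2c2ccc(O)cc2)c1` — in this assay compound 2 gives 3500 nM
Compound 3 `CC(C)(C)C1=NN(c2ccc(Cl)cc2)C(c2ccc(F)cc2)C1` — in this assay compound 3 shows "not determined" (no result reported)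

Going by the values given here, compound 3 has no numerical result in this assay, and compound 1 is the one further entry without a number, so the only measured value is that of compound 2. Compound 4 `CC(C)(C)C1=NN(c2ccc(Cl)cc2)C(c2ccc(O)c(F)c2)C1` differs from compound 3 by 3-fluoro-4-hydroxyphenyl in place of 4-fluorophenyl on a saturated ring carbon — 3-fluoro-4-hydroxyphenyl in place of 4-fluorophenyl on a saturated ring carbon. Among the compounds with values here, no measured step exists for this change, and compound 3 gives no anchor; a direction cannot be stated, and a step beyond the scatter in either sense is possible. Resting on compound 2 with 3500 nM, which also carries a hydroxyphenyl on the saturated ring carbon, compound 4 is expected at 3000 nM, estimated range 700 nM to 13000 nM.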

Compound 4, half-maximal inhibitory concentration: 3800 nM
Estimate against measurement, compound 4: 1.3-fold (0.10 log units) below; the range from low to high includes it.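

No step can be read between compound 3 and compound 4, as compound 3 has no number in this assay. The compounds shown leave open how 3-fluoro-4-hydroxyphenyl compares with 4-fluorophenyl on this core, and nothing available explains the result.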